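Sulfonyl substituent variation: unbound fraction notes

This account rests on a few compounds, and the source may have more. Where it says the series, first, only, none or still open, it means among the compounds named here.

Measured so far:
compound 1 `COCCN(C)S(=O)(=O)c1ccc(C)c(C#Cc2cc(Cl)ccc2OCC(=O)O)c1`: 0.006
compound 2 `CS(=O)(=O)c1ccc(F)c(C#Cc2cc(Cl)ccc2OCC(=O)O)c1`: 0.013
compound 3 `COCCNS(=O)(=O)c1ccc(C)c(C#Cc2cc(Cl)ccc2OCC(=O)O)c1`: "not determined" (no result reported)

Among the measured compounds shown here, in an ADME assay on a cell-free system (plasma, Homo sapiens) (a higher number here means a larger unbound share of the compound, a lower number a smaller unbound share), compound 1 gives 0.006 and compound 2 gives 0.013; these two values stand on their own, with no step worked out between them. Compound 3 has no result in this assay and so stands without a number. Compound 4 `Cc1ccc(S(=O)(=O)N(C)C)cc1C#Cc1cc(Cl)ccc1OCC(=O)O` is the next point and differs from compound 3 by dimethylamino in place of (2-methoxyethyl)amino on a sulfonyl sulfur. For the measured compounds named here, no step between measured compounds is available to size this change, so the expectation for compound 3 to compound 4 in this assay is a step within the scatter, with no direction favoured. Given that compound 1 gives 0.006 and compound 2 gives 0.013, compound 4 is expected near 0.01, in a range from 0.004 to 0.025.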

Compound 4, unbound fraction: 0.004
For compound 4 the middle estimate is 2.5-fold (0.40 log units) above the measured one; the range from low to high includes it.
By their numbers in this assay, from the lowest: compounds 4 and 1 (each within the scatter of the next); then compound 2.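

Among the compounds shown here, the step from compound 3 to compound 4 cannot be read, but this assay now gives a first size for a change at the sulfonamide nitrogen. Hydrogen in place of methoxymethyl on a saturated chain carbon bound to a sulfonamide nitrogen amounts to a 1.5-fold lower number from compound 1 to compound 4 (0.18 log units; within the scatter) and so leaves this pair within the scatter. No evidence at hand bears on this result.

Going by these compounds, whether a longer chain or a morpholine on the sulfonyl sulfur would give a step beyond the scatter remains open. So does the effect of the sulfonamide hydrogen in this series.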